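The source may hold more compounds than are shown below. What is called first, only, known or untested is meant among the compounds shown, and "the series" means these compounds.

Measured so far in an assay on CHO cells for displacement of a labelled ligand from adenosine receptor A3 (Homo sapiens), tested at 1 uM; a higher number here means more inhibition at the concentration tested (going by the name of the read-out), a lower number less inhibition:

compound 1, `O=C(Nc1ccccc1Cl)Nc1nn(-c2ccccc2)c(=O)c2ccccc12`: 49%
compound 2, `O=C(Nc1ccc(Cl)cc1)Nc1nn(-c2ccccc2)c(=O)c2ccccc12`: 13%
compound 3, `O=C(Nc1nn(-c2ccccc2)c(=O)c2ccccc12)c1ccc(Cl)cc1`: 17%

Compound 3 stands second highest of the three numbers in this assay. Its nearest neighbour is compound 2, the gap a number 4 percentage points higher from compound 2 to compound 3 (within the scatter), so the two show nothing beyond the scatter of each other. The furthest is compound 1, with a number 32 percentage points lower from compound 1 to compound 3 (beyond the scatter), and the parallel change on the other branch gives a number 36 percentage points lower from compound 1 to compound 2 (beyond the scatter).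

Compound 4, `Nc1nn(-c2ccccc2)c(=O)c2ccccc12`, is not yet measured. It differs from compound 3 by hydrogen in place of (4-chlorophenyl)carbonyl on a nitrogen on an aromatic ring.

Among the compounds with values here, no measured step removes this group altogether; the two steps from compound 1 each swap one group for another of the same size, and the step from compound 2 to compound 3 exchanges an amino link for a direct carbonyl attachment without a shift beyond the scatter. The change to compound 4 takes away all of the substituent on that nitrogen, so none of the recorded steps is a close model. With the two smaller analogues, compound 2 and compound 3, both already near the low end, the expectation for compound 4 in this assay is a step downward or none beyond the scatter, a number 7 percentage points lower from compound 3 to compound 4 (within the scatter). Compound 4 is therefore estimated at 10%, within -5% to 30%.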

Compound 4, a percentage reported as inhibition, at one concentration (the size of the read-out at that concentration, not a potency): 8%
Estimate against measurement, compound 4: 2 percentage points above; the range from low to high includes it.
By their numbers in this assay, from the lowest: compounds 4, 2 and 3 (each within the scatter of the next); then compound 1.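

Removing the whole (4-chlorophenyl)carbonyl from this nitrogen on an aromatic ring, leaving only hydrogen, gives in this assay a number 9 percentage points lower from compound 3 to compound 4 (within the scatter) and so shows that this substituent, with its 9 heavy atoms and its six-membered aromatic ring of carbon only, adds nothing beyond the scatter at the concentration tested. The earlier steps shown here only exchanged one substituent for another, whereas compound 4 at 8% now gives the reading for the unsubstituted position, and against it compound 1 at 49% is the only case where a substituent here goes with a clearly higher number, with compound 2 and compound 3 showing that substitution alone does not bring this. No measurement in hand explains the result.

As far as these compounds go, whether the chlorine of the 2-chlorophenyl group is needed stays open, and an unsubstituted phenyl or a methoxy group in its place would address that. Also open, from the compounds shown here alone, is how a small acetyl group or a longer alkyl chain on this nitrogen would read in this assay and whether a full concentration series would keep the same order.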